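The source may report more compounds than this note shows. Statements on the series, on what has been measured and on what is new or still open speak of the compounds shown alone.

Measured so far:
compound 1, `OCc1cc(Br)c(O)c(O)c1Br` — 15000 nM
compound 2, `CCCOCc1cc(O)c(O)c(Br)c1` — 26300 nM

In a functional assay on DLD-1 cells (Homo sapiens) for cytotoxicity, read by MTT assay, with a stated time of 96 h (a higher number here means a weaker inhibitor, a lower number a stronger inhibitor), compound 2 gives 26300 nM. Within the data shown here, its only companion is compound 1, which in this assay gives 15000 nM; the two numbers lie within the usual scatter of each other, so neither compound can be set apart from the other on these data. The next compound is compound 3, `CCCOCc1cc(Br)c(O)c(O)c1Br`, which is yet to be measured in this assay. It differs from compound 2 in one place: bromo in place of hydrogen on an aromatic carbon. Among the measured compounds shown here, no step between measured compounds of this study bears on that change, so the expectation rests on the two values alone. The author expects compound 3 to give a number close to that of compound 2, with the step of a 1.5-fold lower number from compound 2 to compound 3 (0.16 log units; within the scatter) staying within the scatter. The author's estimate for compound 3 in this assay is 18000 nM, with a range from 8000 nM to 45000 nM.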

Compound 3, half-maximal inhibitory concentration: 1720 nM
Compound 3: middle estimate off by 10-fold (1.02 log units), on the high side; measured number outside the range, below it.
By their numbers in this assay, from the lowest: compound 3; then compounds 1 and 2 (each within the scatter of the next).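

In this assay the new bromo, on the aromatic carbon ortho to the propoxymethyl group and para to the other bromo group, gives a 15-fold lower number from compound 2 to compound 3 (1.18 log units; beyond the scatter) and so is a large step beyond the scatter, which shows that this position is far from indifferent to the change. With both bromo groups in place, the propyl on the oxygen also counts, giving an 8.7-fold lower number from compound 1 to compound 3 (0.94 log units; beyond the scatter) as a modest step beyond the scatter, so compound 3 lies beyond the scatter of each compound from which it differs in one place. Nothing measured here gives a reason for either step.

The compounds shown leave open whether chloro or methyl at this position would act as bromo does. They also leave open whether a longer chain than propyl on the oxygen would lower the number further.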